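Pyridyl ether series: tolerability in PBMC cytotoxicity

The source may report more compounds than this note shows. Statements on the series, on what has been measured and on what is new or still open speak of the compounds shown alone.

Measured so far in an ADME assay on PBMC cells (Homo sapiens) for cytotoxicity; a higher number here means that more compound is tolerated, a lower number that less compound is tolerated:
- compound 1 `CCO/N=C(/c1ccc(Br)cc1)C1CCN(C(C)CCNC(=O)c2c(Cl)cncc2Cl)CC1`: 33800 nM
- compound 2 `COc1cccc(OC(c2ccc(C(F)(F)F)cc2)C2CCN(C(C)CCNC(=O)c3c(Cl)cncc3Cl)CC2)n1`: 32700 nM
- compound 3 `CCO/N=C(/c1ccc(Br)cc1)C1CCN(C(CC)CCNC(=O)c2c(C)cc[n+]([O-])c2C)CC1`: > 177000 nM, which is a limit of the assay and not a number

Compound 2 stands at the smaller of the two numbers in this assay, but the gap to compound 1 is within the usual scatter, so the two cannot be told apart on these data. Among the compounds with values here, for compound 3 only a limit is known, (the limit of > 177000 nM in this assay, at which 1 of the 3 values shown sits), and it is the sole such value in the set.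

The next compound, compound 4 `Cc1cccc(OC(c2ccc(C(F)(F)F)cc2)C2CCN(C(C)CCNC(=O)c3c(Cl)cncc3Cl)CC2)n1`, differs from compound 2 in one place: methyl in place of methoxy on an aromatic carbon. Cut one bond further out, this is 6-methoxypyridin-2-yl becoming 6-methylpyridin-2-yl. Within the data shown here, no measured pair in this set isolates this change, so there is nothing to lean on beyond the size of the edit itself. The expectation is a step from compound 2 to compound 4 of a 1.0-fold higher number from compound 2 to compound 4 (0.00 log units; within the scatter), that is, none beyond the scatter of this assay. Compound 4 is therefore estimated at 33000 nM, with the likely range running from 15000 nM to 75000 nM.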

Compound 4, half-maximal cytotoxic concentration: 6700 nM
Compound 4: the middle estimate sits 4.9-fold (0.69 log units) above what was measured, outside the stated range (below it).
By their numbers in this assay, from the lowest: compound 4; then compounds 2 and 1 (each within the scatter of the next). At a limit, above all of these: compound 3.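

Within the data shown here, changing 6-methoxypyridin-2-yl to 6-methylpyridin-2-yl gives the only single-place step in this set in this assay, and it reads a 4.9-fold lower number from compound 2 to compound 4 (0.69 log units; beyond the scatter). This position, on an aromatic carbon next to the ring nitrogen, therefore matters for this read-out: a small edit moves the number beyond the scatter, and less compound is tolerated with methyl than with methoxy. Nothing measured here bears on the cause of this step.

As far as these compounds go, whether the step follows from the methyl group itself or from the loss of the methoxy oxygen stays open, as the two are tied together in this one pair. From the compounds shown here alone, how other groups at this position, such as an amine, a chlorine or a longer alkoxy chain, would sit relative to compound 2 and compound 4 also remains open.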